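The compounds below may be only part of what the source reports. "The series", "measured", "known", "first", "only" and "open" are said of these compounds alone.

Measured so far:
compound 1, `Cn1cnc(-c2nc(N)c3cc(Cc4ccccc4)sc3n2)c1`, 2330 nM
compound 2, `Nc1nc(-c2ccccc2)nc2sc(-c3ccccc3)cc12`, 237 nM

Within the data shown here, in a functional assay on CHO-K1 cells for antagonist activity at adenosine receptor A1 (Homo sapiens), read by a beta-galactosidase reporter and cAMP accumulation, with stated times of 15 min and 6 h (a lower number here means a stronger inhibitor, a higher number a weaker inhibitor), compound 2 gives 237 nM, the lower of the two numbers so far, and compound 1 gives 2330 nM, a gap that lies beyond the usual scatter. Compound 1 differs from compound 2 in more than one place, so these two values alone cannot say which part of that change carries the gap.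

Compound 3, `Nc1nc(-c2ccccc2)nc2sc(Cc3ccccc3)cc12`, has not yet been measured in this assay. It differs from compound 2 in a single place: benzyl in place of phenyl on an aromatic carbon. Among the measured compounds shown here, no measured pair in this set shows this one change on its own, so the size of the step cannot be read off directly. Compound 1 carries the same benzyl group but also a different group elsewhere, and its value of 2330 nM is no more than a loose hint that the benzyl group need not help. The step from compound 2 to compound 3 is therefore expected to be modest, most likely a small loss, a 2.1-fold higher number from compound 2 to compound 3 (0.32 log units; beyond the scatter). Compound 3 is estimated to give 500 nM in this assay, with a plausible range from 150 nM to 1800 nM.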

Compound 3, inhibition constant: 151 nM
The estimate for compound 3 lay 3.3-fold (0.52 log units) above the measured number; the range from low to high includes it.
By their numbers in this assay, from the lowest: compounds 3 and 2 (each within the scatter of the next); then compound 1.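

At the aromatic carbon next to the ring sulfur, benzyl in place of phenyl gives, in this assay, a 1.6-fold lower number from compound 2 to compound 3 (0.20 log units; within the scatter), a step within the usual scatter, so the two groups cannot be told apart at this position and the added carbon brings no measurable cost or gain. Among these compounds, compound 3 also gives the first single-change reading of compound 1: with benzyl present in both, phenyl in place of 1-methyl-1H-imidazol-4-yl gives a 15-fold lower number from compound 1 to compound 3 (1.19 log units; beyond the scatter), so the weak number of compound 1 goes with the 1-methyl-1H-imidazol-4-yl group and not with benzyl. Nothing available here explains either step.

On these data alone, both groups seen next to the ring sulfur contain a six-membered aromatic ring of carbon only, so it remains open how this position would respond to a longer chain such as 2-phenylethyl, to a plain methyl group or to an amine. As far as these compounds go, the 1-methyl-1H-imidazol-4-yl group also appears only alongside benzyl, so whether its large step would hold with phenyl next to the ring sulfur is unknown.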